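The source may hold more compounds than are shown below. What is called first, only, known or untested is meant among the compounds shown, and "the series" means these compounds.

Measured in a functional assay on MCF7 cells (Homo sapiens) for antiproliferative activity, read by MTT assay; on this read-out lower numbers stand for stronger inhibition and higher numbers for weaker inhibition:
- compound 1 `COc1ccc([C@@H]2C(c3cc4ccccc4s3)C(=O)N2c2cc(OC)c(OC)c(OC)c2)cc1`: 850 nM
- compound 2 `COc1ccc([C@@H]2[C@@H](c3ccsc3)C(=O)N2c2cc(OC)c(OC)c(OC)c2)cc1O`: 10 nM

Compound 1 holds the higher of the two numbers, and compound 2 lies well below it, a gap beyond the scatter. Among the measured compounds shown here, no measured pair differs in one place only, so no direct step is available.

The next compound is compound 3 `COc1ccc([C@@H]2C(c3ccsc3)C(=O)N2c2cc(OC)c(OC)c(OC)c2)cc1`, which has thiophen-3-yl in place of 1-benzothiophen-2-yl on a saturated ring carbon of the core of compound 1: thiophen-3-yl in place of 1-benzothiophen-2-yl on a saturated ring carbon. Compound 2 also bears thiophen-3-yl and gives 10 nM, but it differs from compound 3 elsewhere too, so it is only a rough guide.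

In this assay, a step to a lower number, beyond the scatter, is expected, and the estimated step is a 14-fold lower number from compound 1 to compound 3 (1.15 log units; beyond the scatter). The expected value for compound 3 is 60 nM, with an estimated range from 15 nM to 250 nM.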

Compound 3, half-maximal inhibitory concentration: 60 nM
For compound 3 middle estimate and measured number coincide at the digits printed; measured number inside the range.
By their numbers in this assay, from the lowest: compound 2; then compound 3; then compound 1.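

In this assay, the saturated ring carbon gives the series its first single-place step, a 14-fold lower number from compound 1 to compound 3 (1.15 log units; beyond the scatter), so the number at this position clearly depends on the aromatic group it carries. The change removes the six-membered aromatic ring of carbon only and keeps a five-membered aromatic ring with one sulfur, taking the group from 9 heavy atoms to 5, so a fused group is not required for a number as low as that of compound 3. No measurement here gives a reason for the size of this step.

The step combines loss of the fused ring with a change of attachment point, and thiophen-2-yl would be needed to separate the two. On these data alone, whether furan-3-yl or phenyl at this carbon would match thiophen-3-yl remains open.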